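Smaller ring on the hydroxy side chain

A few compounds are considered here, and "the series" means these few. Any claim that something is new, unique, unknown or untested is made for them only; others in the source may bear on it.

Measured in an ADME assay on liver for metabolic stability, with Liver microsome (Homo sapiens) as the target, read by LC-MS, using microsomes; on this read-out lower numbers stand for slow clearance and higher numbers for fast clearance:
compound 1 `CC(C)(C)C[C@@H](O)C(=O)N1C[C@@H]2C[C@@H]2[C@H]1C(=O)NCc1cc(Cl)ccc1-n1cnnn1` gives 20 mL.min-1.g-1
compound 2 `O=C(NCc1cc(Cl)ccc1-n1cnnn1)[C@@H]1[C@H]2C[C@H]2CN1C(=O)[C@H](O)Cc1ccccc1` gives 96 mL.min-1.g-1
compound 3 `O=C(NCc1cc(Cl)ccc1-n1cnnn1)[C@@H]1[C@H]2C[C@H]2CN1C(=O)[C@H](O)C1CCCCC1` gives 110 mL.min-1.g-1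

Compound 3, with its 110 mL.min-1.g-1 reading, stands at the high end of this set together with compound 2: the step of a 1.1-fold higher number from compound 2 to compound 3 (0.06 log units; within the scatter) stays within the scatter. The step of a 5.5-fold higher number from compound 1 to compound 3 (0.74 log units; beyond the scatter) sets it apart from compound 1, and the step of a 4.8-fold higher number from compound 1 to compound 2 (0.68 log units; beyond the scatter) is of similar, modest size.

Compound 4 `O=C(NCc1cc(Cl)ccc1-n1cnnn1)[C@@H]1[C@H]2C[C@H]2CN1C(=O)[C@H](O)CC1CC1` differs from compound 3 in one place (cyclopropylmethyl in place of cyclohexyl on a saturated chain carbon bound to a carbonyl carbon and an oxygen on a saturated carbon). Among the compounds with values here, no measured step tests cyclopropylmethyl itself, so the evidence is indirect. The two modest steps up from compound 1 give the only scale available, and they suggest that the smaller group could take back part of that rise. A modest fall in this assay is therefore expected, perhaps only just beyond the scatter.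

The expected step is a 2.4-fold lower number from compound 3 to compound 4 (0.39 log units; beyond the scatter) in this estimate. For compound 4 the estimated value is 45 mL.min-1.g-1 with an expected range from 20 mL.min-1.g-1 to 100 mL.min-1.g-1 for the measurement.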

Compound 4, intrinsic clearance in microsomes: < 14 mL.min-1.g-1
Compound 4 ended at the assay's limit (the forecaster's own chance of this, stated with the estimate: 3%); at least 3.2-fold (0.50 log units) between middle value and limit.
By their numbers in this assay, from the lowest: compound 1; then compounds 2 and 3 (each within the scatter of the next). At a limit, below all of these: compound 4.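

In this assay, the position on the saturated chain carbon bound to a carbonyl carbon and an oxygen on a saturated carbon turns out to tolerate a ring-bearing group at the low end of the read-out: the change gives an at least 7.8-fold lower number from compound 3 to compound 4 (0.89 log units; beyond the scatter), and the comparison with the phenyl compound gives an at least 6.8-fold lower number from compound 2 to compound 4 (0.83 log units; beyond the scatter), so the high numbers of compounds 2 and 3 do not follow from a ring alone. Against the tert-butyl compound, the change gives an at least 1.4-fold lower number from compound 1 to compound 4 (0.15 log units; that floor lies within the scatter), which does not separate the two. The reading of compound 4 is a limit of the assay and not a number: the limit of < 14 mL.min-1.g-1 in this assay, at which 1 of the 4 values shown sits.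

On these data alone, how far compound 4 lies under that limit remains open, and with it its order against compound 1. The compounds shown also leave open how a tetrahydropyranyl ring or an amine at this position would read in this assay.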